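Swapping a Methylphenyl Arm for Naphthyl

The source may hold more compounds than are shown below. What is called first, only, known or untested is meant among the compounds shown, and "the series" means these compounds.

Three measured compounds share one core and differ only in the arm hanging from the triazole nitrogen. Compound 1 `Brc1ccc(Cn2cc(CSc3nnc(-c4ccccc4)c(-c4ccccc4)n3)nn2)cc1` carries a bromo group on that arm, compound 2 `Cc1ccc(Cn2cc(CSc3nnc(-c4ccccc4)c(-c4ccccc4)n3)nn2)cc1` has a methyl in its place, and compound 3 `COc1ccc(C(=O)/C=C/c2ccc(-n3cc(CSc4nnc(-c5ccccc5)c(-c5ccccc5)n4)nn3)cc2)cc1` carries a much larger arm. In a functional assay on PC-3 cells (Homo sapiens) for antiproliferative activity, read by MTT assay, with a stated time of 48 h (a lower number here means a stronger inhibitor, a higher number a weaker inhibitor), compound 1 gives 22000 nM and compound 2 gives 22600 nM. The step of a 1.0-fold higher number from compound 1 to compound 2 (0.01 log units; within the scatter) shows that the two are indistinguishable. Compound 3 gives > 100000 nM in this assay, which is a limit of the assay and not a number; the limit of > 100000 nM in this assay, at which 1 of the 3 values shown sits, marks that edge. Among the two numbers, compound 2 has the higher one, with compound 1 sitting within the scatter of it.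

Compound 4 `c1ccc(-c2nnc(SCc3cn(Cc4ccc5ccccc5c4)nn3)nc2-c2ccccc2)cc1` changes the arm of compound 2 by naphthalen-2-yl in place of 4-methylphenyl on a saturated chain carbon bound to an aromatic nitrogen, so a second fused ring enters where a single ring stood. Within the data shown here, the only measured step that bears on this position is the bromo-to-methyl exchange, which was within the scatter, while the far larger arm of compound 3 leaves only a limit. The naphthyl change is larger than the first but much smaller than the second, so no step beyond the scatter is expected: compound 4 is estimated to give 25000 nM in this assay, between 8000 nM and 80000 nM, meaning an expected step of a 1.1-fold higher number from compound 2 to compound 4 (0.04 log units; within the scatter).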

Compound 4, half-maximal inhibitory concentration: > 100000 nM
Compound 4: a limit, no number; the forecaster's own chance of this, stated with the estimate: 15%; at least 4.0-fold (0.60 log units) between middle value and limit.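

The bromo-to-methyl exchange left the number unmoved, so the arm might have seemed free to vary, but the ring itself turns out to matter. Naphthalen-2-yl in place of 4-methylphenyl gives an at least 4.4-fold higher number from compound 2 to compound 4 (0.64 log units; beyond the scatter), and in place of 4-bromophenyl it gives an at least 4.5-fold higher number from compound 1 to compound 4 (0.65 log units; beyond the scatter), so adding a second fused ring on this saturated chain carbon makes the compound clearly weaker, although no hydrogen-bond donor or acceptor enters or leaves. The result for compound 4 is a limit and not a number, so the full size of the step stays unknown, and compound 4 now stands at the same edge as compound 3: the limit of > 100000 nM in this assay, at which 2 of the 4 values shown sit.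

The compounds shown leave open whether only the second fused ring has this effect. They also do not show how a single ring carrying an amine or a carboxylic acid in place of the methyl would read.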